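The source may report more compounds than this note shows. Statements on the series, on what has been measured and on what is new or still open speak of the compounds shown alone.

In a functional assay on CCRF-CEM cells (Homo sapiens) for antiproliferative activity, read by cell counting, with a stated time of 2 days (on this read-out lower numbers stand for stronger inhibition and higher numbers for weaker inhibition), compound 1 (`COc1cc(C(=O)c2sc(N)nc2N)cc(OC)c1OC`) gives 42000 nM while compound 2 (`COc1cc(C(=O)c2sc(N3CCCCC3)nc2N)cc(OC)c1OC`) gives 22000 nM on the same core. Among the compounds with values here, the one measured step is a 1.9-fold lower number from compound 1 to compound 2 (0.28 log units; within the scatter) and it lies within the scatter. It concerns a different place, so it gives no size for the change at hand.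

Compound 3 (`COc1cccc(C(=O)c2sc(N3CCCC3)nc2N)c1`) has > 200000 nM as a limit and not a number in this assay and this is the limit of > 200000 nM in this assay, at which 1 of the 3 values shown sits.

Compound 4 (`Nc1nc(N2CCCC2)sc1C(=O)c1ccccc1`) has hydrogen in place of methoxy on an aromatic carbon, meta to a large group: hydrogen in place of methoxy on an aromatic carbon.

Within the data shown here, no measured step covers this change, so no shift beyond the scatter is expected. The expected step is a step that the limit leaves unreadable from compound 3 to compound 4 and another reading at the limit is likely. For compound 4 the estimated value is 250000 nM with an expected range of 100000 nM to 600000 nM.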

Compound 4, half-maximal inhibitory concentration: > 200000 nM
Compound 4 ended at the assay's limit; the forecaster's own chance of this, stated with the estimate: 70%; the middle value lies beyond the limit too.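

Compound 3 and compound 4 both stand at a limit in this assay and not at a number, so no step between them can be read: the limit of > 200000 nM in this assay, at which 2 of the 4 values shown sit.

The compounds shown leave open whether hydrogen in place of methoxy shifts the read-out at all.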